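The compounds below may be only part of what the source reports. "The series", "measured", "known", "first", "only" and "open" are said of these compounds alone.

Measured compounds:
Compound 1 `Nc1nc(N)c2cc(CSC(=S)N3CCN(c4ccc([N+](=O)[O-])cc4)CC3)ccc2n1`: 3320 nM
Compound 2 `Nc1nc(N)c2cc(CSC(=S)N3CCN(c4ccccc4[N+](=O)[O-])CC3)ccc2n1`: 4310 nM

In a functional assay on HT-29 cells (Homo sapiens) for antiproliferative activity, read by MTT assay, with a stated time of 72 h (a higher number here means a weaker inhibitor, a lower number a stronger inhibitor), compound 2 gives 4310 nM, and compound 1 gives 3320 nM. These two values sit within the usual scatter of each other, so compound 2 cannot be ranked against compound 1.

Compound 3 `Nc1nc(N)c2cc(CSC(=S)N3CCN(c4ncccn4)CC3)ccc2n1` keeps the shared core and the ring bearing the amine nitrogen, but carries pyrimidin-2-yl in place of 2-nitrophenyl on an amine nitrogen in a ring.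

Among the compounds with values here, only one measured step bears on this change: a 1.3-fold higher number from compound 1 to compound 2 (0.11 log units; within the scatter). It swaps one nitrophenyl group for another, so it says little about a new ring. Within the data shown here, no measured compound shows the effect of losing the nitrophenyl group. With no firm basis for a direction, no step beyond the scatter is expected, though the uncertainty is wide.

The expected change is a 1.1-fold lower number from compound 2 to compound 3 (0.05 log units; within the scatter). Compound 3 is estimated at 3800 nM, with an expected range from 1300 nM to 11000 nM.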

Compound 3, half-maximal inhibitory concentration: 4720 nM
Beside the measured number, compound 3's estimate is 1.2-fold (0.09 log units) below it; low and high end bracket the measured number.
By their numbers in this assay, from the lowest: compounds 1, 2 and 3 (each within the scatter of the next).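

The earlier pair only exchanged one nitrophenyl group for another, whereas compound 3 removes the nitro group and puts a six-membered aromatic ring with 2 hetero atoms on the amine nitrogen in a ring. In this assay, this exchange gives a 1.1-fold higher number from compound 2 to compound 3 (0.04 log units; within the scatter), and the comparison with the other nitrophenyl compound gives a 1.4-fold higher number from compound 1 to compound 3 (0.15 log units; within the scatter). The three compounds therefore cannot be ranked, so a nitro group is not required for activity in this range among these compounds, and nothing available explains this closeness.

On these data alone, what remains open is whether any group on this nitrogen can move the number beyond the scatter. A compound with a small methyl group, or with a phenyl ring carrying a carboxylic acid, would test whether an aromatic ring matters here at all.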